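This account rests on a few compounds, and the source may have more. Where it says the series, first, only, none or still open, it means among the compounds named here.

Measured values in a functional assay on the whole organism (strain Swiss Albino) for inhibition, with Mus musculus as the target, in the writhing test, with a stated time of 1 h, at a dose of 100 mg/kg by the oral route; on this read-out higher numbers stand for more inhibition at the one dose given (going by the name of the read-out) and lower numbers for less inhibition: compound 1 `COc1cc2c(cc1OC)C(CC(=O)O)CC2` gives 44%; compound 2 `COc1cc2c(cc1OC)C(CC(=O)Nc1ccc(Cl)cc1)CC2` gives 73.6%; compound 3 `COc1cc2c(cc1OC)C(CC(=O)Nc1cccc(C)c1)CC2` gives 54.3%.

Compound 3 stands second highest of the three numbers: a number 10.3 percentage points higher from compound 1 to compound 3 (beyond the scatter), while a number 19.3 percentage points lower from compound 2 to compound 3 (beyond the scatter). Both steps are modest, and the larger of them, a number 29.6 percentage points higher from compound 1 to compound 2 (beyond the scatter), comes from turning the acid into an amide.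

Compound 4 `COc1cc2c(cc1OC)C(CC(=O)Nc1ccccn1)CC2` differs from compound 3 only on the amide-type nitrogen: pyridin-2-yl in place of 3-methylphenyl on an amide-type nitrogen. For the measured compounds named here, the one measured step at this place is a number 19.3 percentage points lower from compound 2 to compound 3 (beyond the scatter), a modest swap of one aryl group for another. Going by the values given here, no measured compound carries a ring with a hetero atom, so that step gives only a rough scale for this read-out. A modest step in either direction, or none beyond the scatter, is expected here.

For compound 4 the estimate is 55%, between 38% and 72%, which is an expected step of a number 0.7 percentage points higher from compound 3 to compound 4 (within the scatter).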

Compound 4, a percentage reported as inhibition, in the whole organism at one dose (the size of the read-out at that dose, not a potency): 48.1%
Beside the measured number, compound 4's estimate is 6.9 percentage points above it; the range from low to high includes it.
By their numbers in this assay, from the lowest: compounds 1, 4 and 3 (each within the scatter of the next, the first and the last beyond it); then compound 2.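

In this assay pyridin-2-yl on the amide-type nitrogen stays within the scatter of 3-methylphenyl, a step of a number 6.2 percentage points lower from compound 3 to compound 4 (within the scatter), and the ring with a hetero atom leaves the amide within the scatter of the acid, a step of a number 4.1 percentage points higher from compound 1 to compound 4 (within the scatter). Making an amide from the acid therefore does not always carry the read-out beyond the scatter, whereas the step of a number 25.5 percentage points lower from compound 2 to compound 4 (beyond the scatter) keeps the 4-chlorophenyl amide apart. Going by these compounds, whether pyridin-4-yl or 4-methylphenyl on this nitrogen would come closer to compound 2 remains open. No measured evidence accounts for these steps.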